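Benzyloxy in place of difluorobenzyloxy on the sulfonyl core

The source may hold more compounds than are shown below. What is called first, only, known or untested is meant among the compounds shown, and "the series" means these compounds.

The measured compounds:
Compound 1, `O=C(O)c1cccc(C2=C(c3cc(Br)ccc3OCc3ccc(F)cc3F)CCC2)c1`, gives 5.01 nM in an assay on isolated protein for inhibition of prostaglandin E2 receptor EP1 subtype (Homo sapiens); on this read-out higher numbers stand for weaker inhibition and lower numbers for stronger inhibition.
Compound 2, `O=C(O)c1cccc(C2=C(c3cc(Br)ccc3OCc3ccccc3)CCC2)c1`, gives 12.6 nM in this assay.
Compound 3, `CS(=O)(=O)c1ccc(OCc2ccc(F)cc2F)c(C2=C(c3cccc(C(=O)O)c3)CCC2)c1`, gives 15.9 nM in this assay.

Compound 3 and compound 1 share a core that differs in one place: methylsulfonyl in place of bromo on an aromatic carbon. That change gave a 3.2-fold higher number from compound 1 to compound 3 (0.50 log units; beyond the scatter). Compound 4, `CS(=O)(=O)c1ccc(OCc2ccccc2)c(C2=C(c3cccc(C(=O)O)c3)CCC2)c1`, has not yet been measured; it differs from compound 3 in one place: phenyl in place of 2,4-difluorophenyl on a saturated chain carbon bound to an oxygen on an aromatic ring. The same change was already made on the core of compound 1: phenyl in place of 2,4-difluorophenyl on a saturated chain carbon bound to an oxygen on an aromatic ring, with a 2.5-fold higher number from compound 1 to compound 2 (0.40 log units; beyond the scatter). The place is described in the same words for both pairs, so this is the same change on the two cores.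

For the measured compounds named here, with only one earlier instance of this change, the expectation for compound 4 rests on compound 3 at 15.9 nM and on the step of a 2.5-fold higher number from compound 1 to compound 2 (0.40 log units; beyond the scatter). Compound 4 is therefore expected to show about a 2.5-fold higher number from compound 3 to compound 4 (0.40 log units; beyond the scatter) in this assay. The estimate for compound 4 is 40 nM, with a likely range from 18 nM to 90 nM.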

Compound 4, half-maximal inhibitory concentration: 79.4 nM
Compound 4: the middle estimate sits 2.0-fold (0.30 log units) below what was measured, and the stated range covers the measured number.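

In this assay, phenyl in place of 2,4-difluorophenyl on the methylsulfonyl core gave a 5.0-fold higher number from compound 3 to compound 4 (0.70 log units; beyond the scatter), and this step agrees with the one on the bromo core: the same change on two cores in this assay, a 2.5-fold higher number (0.40 log units; beyond the scatter) from compound 1 to compound 2 and a 5.0-fold higher number (0.70 log units; beyond the scatter) from compound 3 to compound 4, 2.0-fold (0.30 log units) apart, within the scatter of two such steps. Methylsulfonyl in place of bromo, read on the cores that carry phenyl, gave a 6.3-fold higher number from compound 2 to compound 4 (0.80 log units; beyond the scatter), and this step agrees in the same way with its earlier instance: the same change on two cores in this assay, a 3.2-fold higher number (0.50 log units; beyond the scatter) from compound 1 to compound 3 and a 6.3-fold higher number (0.80 log units; beyond the scatter) from compound 2 to compound 4, 2.0-fold (0.30 log units) apart, within the scatter of two such steps. Both changes thus kept their direction from one core to the other, with sizes that cannot be told apart, but these four compounds form a single set of two pairs for each change and do not show that either step would hold on any further core.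

The compounds shown leave open whether a chlorobenzyl group in place of the 2,4-difluorobenzyl group, or a nitrile or a chloro group in place of bromo and methylsulfonyl, would follow the same pattern. They also leave open whether these steps would persist with an amide in place of the carboxylic acid.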